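The source may hold more compounds than are shown below. What is called first, only, known or untested is meant among the compounds shown, and "the series" means these compounds.

Measured so far:
compound 1, `CC(=O)OCc1ccc2oc(=O)c(C(=O)Nc3cccc(Cl)c3)cc2c1`: 79.6%
compound 2, `CCCCC(=O)OCc1ccc2oc(=O)c(C(=O)Oc3cccc(Br)c3)cc2c1`: 92.4%

In a functional assay on HT-1080 cells (Homo sapiens), read by transwell migration, with a stated time of 24 h, tested at 0.1 uM (a higher number here means a weaker effect of the compound at the concentration tested, a lower number a stronger effect), compound 2 gives 92.4%, the highest of the two numbers; compound 1 gives 79.6%, a gap beyond the usual scatter. Within the data shown here, no step between compounds differing in one place is available, so the move from compound 2 to compound 3, `CC(=O)NCc1ccc2oc(=O)c(C(=O)Oc3cccc(Br)c3)cc2c1`, rests on the change alone: acetamido in place of (butylcarbonyl)oxy on a saturated chain carbon bound to an aromatic carbon. Without a comparable pair, the step in this assay is expected to be small, most likely within the scatter, with no firm direction. Compound 3 is estimated at 88%, range 70% to 105%, an expected step of a number 4.4 percentage points lower from compound 2 to compound 3 (within the scatter).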

Compound 3, a percentage reported as activity, at one concentration (the size of the read-out at that concentration, not a potency): 34.4%
Compound 3: middle estimate off by 53.6 percentage points, on the high side; measured number outside the range, below it.
By their numbers in this assay, from the lowest: compound 3; then compound 1; then compound 2.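

In this assay the saturated chain carbon bound to an aromatic carbon proves highly sensitive to its substituent. With the rest of the structure unchanged, acetamido in place of (butylcarbonyl)oxy gives a number 58 percentage points lower from compound 2 to compound 3 (beyond the scatter) and thus a much stronger effect at the concentration tested. No supporting measurement bears on why this step is so large. Still open, on these data alone, is whether the step reflects the arrival of acetamido or the loss of (butylcarbonyl)oxy. A free amine or a longer chain on the amide carbonyl at this place would help separate the two.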